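The source may report more compounds than this note shows. Statements on the series, on what has been measured and on what is new or still open speak of the compounds shown alone.

Measured in a functional assay on Jurkat cells (Homo sapiens) for inhibition, read by MTT assay, with a stated time of 72 h; on this read-out lower numbers stand for stronger inhibition of growth and higher numbers for weaker inhibition of growth:

Compound 1 `COC(=O)c1nc(C)n(-c2ccccc2C(F)(F)F)n1` gives > 100000 nM, which is a limit of the assay and not a number.
Compound 2 `COC(=O)c1nc(C)n(-c2cccc(Br)c2)n1` gives > 100000 nM, likewise a limit of the assay.
Compound 3 `COC(=O)c1nc(C)n(-c2ccc(C(F)(F)F)cc2)n1` gives 9100 nM.

Within the data shown here, compound 3 is therefore the only member of this set for which this assay returns an actual number; the other two entries sit at the limit of > 100000 nM in this assay, at which 2 of the 3 values shown sit, so no ordering among the three can be drawn beyond saying that compound 3 alone falls inside the measurable window. No pair of these compounds differs in a single place, so no measured step is available to calibrate the change now in question.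

Compound 4 `COC(=O)c1nc(C)n(-c2ccc(F)cc2)n1`, still to be measured in this assay, differs from compound 3 by fluoro in place of trifluoromethyl on an aromatic carbon. Among the measured compounds shown here, with no measured step to lean on, the expectation can only be framed loosely: the step from compound 3 to compound 4 is expected to be a 2.2-fold higher number from compound 3 to compound 4 (0.34 log units; beyond the scatter), a modest move toward weaker inhibition rather than a change beyond recognition, though a result within the scatter would not surprise. On that basis compound 4 is estimated at 20000 nM in this assay, with a plausible range from 5000 nM to 100000 nM, and a real chance that only a limit is reported.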

Compound 4, concentration for 50% growth inhibition: 8700 nM
For compound 4 the middle estimate is 2.3-fold (0.36 log units) above the measured one, and the stated range covers the measured number.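

In this assay, the exchange of trifluoromethyl for fluoro at this aromatic carbon, para to a large group, gives a 1.0-fold lower number from compound 3 to compound 4 (0.02 log units; within the scatter), so the two compounds cannot be told apart on this read-out. Among these compounds, this is the first measured step in the set, and it shows that at this place a group of 4 heavy atoms and a group of 1 heavy atom give the same result within the usual scatter, so compound 3 no longer stands alone inside the measurable window. The entries of compound 1 and compound 2 remain limits of the assay and not numbers, and they take no part in this step: the limit of > 100000 nM in this assay, at which 2 of the 4 values shown sit.

As far as these compounds go, both groups seen at this carbon are fluorinated, so it remains open whether an amine, a methoxy group or a carboxylic acid at the same place would return a value in the same range, or whether a plain hydrogen there would do so. Among the compounds shown here, the methyl ester is also an open question, as all four compounds carry it and no step shows what a carboxylic acid or an amide in its place would give.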